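A few compounds are considered here, and "the series" means these few. Any claim that something is new, unique, unknown or untested is made for them only; others in the source may bear on it.

The measured compounds in a functional assay on the whole organism (strain Sprague-Dawley) for inhibition, with Rattus norvegicus as the target; on this read-out lower numbers stand for an effect already at smaller amounts and higher numbers for an effect only at larger amounts of compound:

Compound 1 `O=c1c(-c2nn[nH]n2)c[nH]c2ccccc12` gives 1.25 mg/kg.
Compound 2 `O=c1c(-c2nn[nH]n2)c[nH]c2ccc(Cl)cc12` gives only a limit of the assay, > 10 mg/kg.
Compound 3 `Cc1ccc2[nH]cc(-c3nn[nH]n3)c(=O)c2c1` gives 1.25 mg/kg.

Compound 1 stands level with compound 3 at the digits shown, and the two are within the scatter of each other. Of the three compounds, only compound 2 returns a limit rather than a number (the limit of > 10 mg/kg in this assay, at which 1 of the 3 values shown sits).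

Compound 4 `CC(C)c1cccc2c(=O)c(-c3nn[nH]n3)c[nH]c12` differs from compound 1 in one place: isopropyl in place of hydrogen on an aromatic carbon. Among the compounds with values here, two measured steps bear on this change. The step of no change at the digits printed from compound 1 to compound 3 (within the scatter) shows that a small alkyl group on an aromatic carbon of the shared core leaves the read-out where it was. The step of an at least 8.0-fold higher number from compound 1 to compound 2 (0.90 log units; beyond the scatter) shows that a chloro group on an aromatic carbon pushes the read-out beyond the measurable range. Isopropyl is a larger alkyl group than methyl, and no measured compound carries a substituent of that size, so the expectation rests on the methyl result with an allowance for the chloro result. Compound 4 is therefore expected to lie close to compound 1, with the step of a 2.0-fold higher number from compound 1 to compound 4 (0.30 log units; within the scatter) estimated as small and directed toward higher numbers. The estimate for compound 4 is 2.5 mg/kg, with a range from 1 mg/kg to 10 mg/kg.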

Compound 4, minimum effective dose: 1.25 mg/kg
Beside the measured number, compound 4's estimate is 2.0-fold (0.30 log units) above it, and the stated range covers the measured number.
By their numbers in this assay, from the lowest: compounds 1, 3 and 4 (each within the scatter of the next). At a limit, above all of these: compound 2.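

Across this assay, the result no change at the digits printed from compound 1 to compound 4 (within the scatter) shows that an aromatic carbon of the shared core, ortho to a fused ring and meta to a fused ring, carries isopropyl, a branched group of 3 heavy atoms, with the read-out staying within the scatter of compound 1. Within the data shown here, until now, methyl in compound 3 was the only alkyl group on the core, so the tolerance seen for alkyl substitution now reaches a larger group and a second place on the core. The contrast with the chloro group remains, as compound 2 is still the only compound that gives a limit rather than a number: the limit of > 10 mg/kg in this assay, at which 1 of the 4 values shown sits.

The compounds shown leave open whether a chloro group at the carbon bearing isopropyl in compound 4 would also end at a limit, and whether isopropyl at the carbon bearing chloro in compound 2 would match compound 1. They also leave open how far this carbon tolerates other groups, such as an amine, a carboxylic acid or a longer alkyl chain.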